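This account rests on a few compounds, and the source may have more. Where it says the series, first, only, none or still open, it means among the compounds named here.

Series notes. The shared core of compound 1 `Cc1c(C(=O)N/N=C\c2ccccn2)oc2cccc(O)c12` carries a pyridin-2-yl group on the carbon with a double bond to nitrogen; in a functional assay on PC-3 cells (Homo sapiens) for inhibition (on this read-out lower numbers stand for stronger inhibition and higher numbers for weaker inhibition), compound 1 gives only the limit >= 40000 nM, which is a limit of the assay and not a number. Compound 2 `Cc1c(C(=O)N/N=C\c2cccc(O)c2)oc2cccc(O)c12` gives 17600 nM in this assay, and compound 3 `Cc1c(C(=O)N/N=C\c2cccc(Br)c2O)oc2cccc(O)c12` gives 16600 nM. Compound 3 thus holds the lowest of the two numbers, with compound 2 nearest; the step of a 1.1-fold lower number from compound 2 to compound 3 (0.03 log units; within the scatter) lies within the scatter, so no order between them is claimed. The steps of an at least 2.2-fold lower number from compound 1 to compound 2 (0.35 log units; beyond the scatter) and an at least 2.4-fold lower number from compound 1 to compound 3 (0.38 log units; beyond the scatter) are both beyond the scatter and point the same way, in favour of the 3-hydroxyphenyl and 3-bromo-2-hydroxyphenyl groups.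

Compound 4 `Cc1c(C(=O)N/N=C\c2ccc(O)cc2O)oc2cccc(O)c12` differs from compound 3 as follows: 2,4-dihydroxyphenyl in place of 3-bromo-2-hydroxyphenyl on a carbon with a double bond to nitrogen. The step that bears most on this change is a 1.1-fold lower number from compound 2 to compound 3 (0.03 log units; within the scatter), where exchanging 3-hydroxyphenyl for 3-bromo-2-hydroxyphenyl moved the number only within the scatter. The step of a 1.0-fold lower number from compound 3 to compound 4 (0.02 log units; within the scatter) in this assay is therefore expected to be none beyond the scatter. The estimate for compound 4 in this assay is 16000 nM, ranging from 6000 nM to 40000 nM.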

Compound 4, half-maximal inhibitory concentration: 14800 nM
Compound 4: the middle estimate sits 1.1-fold (0.03 log units) above what was measured, within the range that was stated.
By their numbers in this assay, from the lowest: compounds 4, 3 and 2 (each within the scatter of the next). At a limit, above all of these: compound 1.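

In this assay, the change from 3-bromo-2-hydroxyphenyl to 2,4-dihydroxyphenyl gives a 1.1-fold lower number from compound 3 to compound 4 (0.05 log units; within the scatter), and the change from 3-hydroxyphenyl gives a 1.2-fold lower number from compound 2 to compound 4 (0.08 log units; within the scatter), so on this carbon these three hydroxyphenyl groups cannot be told apart, with or without the bromine. Replacing pyridin-2-yl with 2,4-dihydroxyphenyl gives an at least 2.7-fold lower number from compound 1 to compound 4 (0.43 log units; beyond the scatter), a third step in the same direction as the two already seen from that group. From the compounds shown here alone, compound 1 supplies a limit of the assay and not a number, so the true size of this step stays unknown: the limit of >= 40000 nM in this assay, at which 1 of the 4 values shown sits.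

Still open, going by these compounds, is whether an unsubstituted phenyl, or a phenyl carrying an amine or a carboxylic acid, would fall in the same range. The compounds shown also cannot separate the role of the pyridine nitrogen from that of the absent hydroxyl.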